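This account rests on a few compounds, and the source may have more. Where it says the series, first, only, none or still open, it means among the compounds named here.

Measured so far:
compound 1, `CCOC(=O)c1c(-c2ccc(OC)cc2)oc2ccc(OCCCCCN3C(=O)C(=O)c4cc(F)ccc43)cc12`: 128000 nM
compound 2, `CCOC(=O)c1c(-c2ccc(OC)cc2)oc2ccc(OCCCCN3C(=O)C(=O)c4cc(OC)ccc43)cc12`: 64000 nM

Both values come from an ADME assay on Vero cells (Chlorocebus sabaeus) for cytotoxicity, read by MTT assay, with a stated time of 72 h; on this read-out lower numbers stand for higher toxicity in this test and higher numbers for lower toxicity in this test. Compound 1 gives the larger number of the two, but its gap to compound 2 is within the usual scatter of repeated measurements, so the two compounds cannot be told apart on this read-out.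

Compound 3, `CCOC(=O)c1c(-c2ccc(OC)cc2)oc2ccc(OCCCCCCN3C(=O)C(=O)c4ccccc43)cc12`, has not been measured yet. Relative to compound 1 the change is a group of 12 heavy atoms (9 carbon, 1 nitrogen, 2 oxygen; one five-membered non-aromatic ring with 1 hetero atom, one six-membered aromatic ring of carbon only) in place of a group of 12 heavy atoms (8 carbon, 1 nitrogen, 2 oxygen, 1 fluorine; one five-membered non-aromatic ring with 1 hetero atom, one six-membered aromatic ring of carbon only), on a saturated chain carbon, five bonds along the chain from an oxygen on an aromatic ring; in plain words, the fluorine on the aromatic ring of the side group is gone and the chain linking that group to the core is one carbon longer. Among the compounds with values here, no pair among the measured compounds shows what such a change does in this assay. Within the data shown here, since the only two numbers known sit within the scatter of each other, the expectation for compound 3 is a step of a 1.3-fold lower number from compound 1 to compound 3 (0.11 log units; within the scatter), that is, no change beyond the scatter. The estimated value for compound 3 is 100000 nM, with a range from 40000 nM to 250000 nM.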

Compound 3, half-maximal cytotoxic concentration: 256000 nM
Compound 3: middle estimate off by 2.6-fold (0.41 log units), on the low side; measured number outside the range, above it.
By their numbers in this assay, from the lowest: compounds 2, 1 and 3 (each within the scatter of the next, the first and the last beyond it).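

In this assay, taking the fluorine off the aromatic ring of the side group and making the chain one carbon longer gives a 2.0-fold higher number from compound 1 to compound 3 (0.30 log units; within the scatter) and so stays within the usual scatter. Within the data shown here, this is the first comparison here of compounds that differ in one place, on a saturated chain carbon, five bonds along the chain from an oxygen on an aromatic ring, and on this read-out compound 1 and compound 3 cannot be told apart. Nothing on hand offers an explanation for this result.

Going by these compounds, both edits arrive together, so what the fluorine alone does and what the extra chain carbon alone does both stay open. Also open, on these data alone, is whether a nitrile or a trifluoromethyl on that aromatic ring, or an amine in place of the whole side group, would move the number beyond the scatter.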